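The compounds below may be only part of what the source reports. "The series", "measured", "known", "first", "only" and "open" are said of these compounds alone.

Measured so far in a functional assay on HeLa cells (Homo sapiens) for inhibition, read by MTT assay, with a stated time of 48 h; on this read-out higher numbers stand for weaker inhibition and lower numbers for stronger inhibition:
- compound 1 `COc1ccc2c(=O)c(/C=C/C(=O)Nc3ccc(C)cc3)coc2c1`, which gives 24100 nM
- compound 2 `COc1ccc2c(=O)c(/C=C/C(=O)NCc3ccc(C)cc3)coc2c1`, for which this assay reports only a limit, > 100000 nM
- compound 3 `COc1ccc(NC(=O)/C=C/c2coc3cc(OC)ccc3c2=O)cc1`, which gives 13000 nM

Compound 3 carries the lowest of the two numbers, yet a 1.9-fold lower number from compound 1 to compound 3 (0.27 log units; within the scatter) shows that compound 1 cannot be told apart from it. Compound 4 `COc1ccc2c(=O)c(/C=C/C(=O)Nc3ccccc3C)coc2c1` differs from compound 3 by 2-methylphenyl in place of 4-methoxyphenyl on an amide-type nitrogen. For the measured compounds named here, only one measured step bears on this: a 1.9-fold lower number from compound 1 to compound 3 (0.27 log units; within the scatter), where methoxy and methyl traded places without leaving the scatter. Going by the values given here, no measured pair speaks to moving a group to another spot on that ring. A step no larger than the scatter is therefore expected, as a 1.7-fold higher number from compound 3 to compound 4 (0.23 log units; within the scatter). Compound 4 is estimated at 22000 nM, within a range from 8000 nM to 70000 nM.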

Compound 4, half-maximal inhibitory concentration: 7270 nM
Beside the measured number, compound 4's estimate is 3.0-fold (0.48 log units) above it; measured number outside the range, below it.
By their numbers in this assay, from the lowest: compounds 4, 3 and 1 (each within the scatter of the next, the first and the last beyond it). At a limit, above all of these: compound 2.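

In this assay 2-methylphenyl in place of 4-methylphenyl gives a step beyond the scatter (a 3.3-fold lower number from compound 1 to compound 4 (0.52 log units; beyond the scatter)), the first sign that where the methyl sits on this ring matters. Against 4-methoxyphenyl the same group stays within the scatter (a 1.8-fold lower number from compound 3 to compound 4 (0.25 log units; within the scatter)), so compound 3 and compound 4 cannot be told apart. Against 4-methylbenzyl the gap is large (an at least 13-fold lower number from compound 2 to compound 4 (1.13 log units; beyond the scatter)).

On these data alone, whether an amine or a carboxylic acid on this ring would be tolerated stays open. So does the true size of that large gap, as compound 2 gives only a limit: the limit of > 100000 nM in this assay, at which 1 of the 4 values shown sits.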